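A Phenylsulfonyl Group on the Ring Nitrogen of Compound 3

A few compounds are considered here, and "the series" means these few. Any claim that something is new, unique, unknown or untested is made for them only; others in the source may bear on it.

Measured so far in a functional assay on NCI-H460 cells (Homo sapiens) for cytotoxicity, read by MTT assay, with a stated time of 3 days (on this read-out lower numbers stand for stronger inhibition and higher numbers for weaker inhibition), for three compounds:
compound 1 `N#Cc1c(Nc2ccccc2)nc(SCc2nc3ccccc3[nH]2)nc1-c1ccccc1` gives 4.54 nM as its value
compound 2 `N#Cc1c(Nc2nccs2)nc(SCc2nc3ccccc3[nH]2)nc1-c1ccccc1` gives 3.37 nM as its value
compound 3 `N#Cc1c(-c2ccccc2)nc(SCc2nc3ccccc3[nH]2)nc1N1CCNCC1` gives 7.35 nM as its value

Compound 3 stands at 7.35 nM on this scale. The comparisons show a 1.6-fold higher number from compound 1 to compound 3 (0.21 log units; within the scatter) and also a 2.2-fold higher number from compound 2 to compound 3 (0.34 log units; beyond the scatter) so only compound 2 separates from it, and only modestly.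

Compound 4 `N#Cc1c(-c2ccccc2)nc(SCc2nc3ccccc3[nH]2)nc1N1CCN(S(=O)(=O)c2ccccc2)CC1` carries phenylsulfonyl in place of hydrogen on an amine nitrogen in a ring, and the full difference is phenylsulfonyl in place of hydrogen on an amine nitrogen in a ring as counted from the two structures. Within the data shown here, no measured step touches that nitrogen, so the data hold no direct precedent for this change. The nearest evidence comes from exchanges on the aromatic carbon, and a 1.6-fold higher number from compound 1 to compound 3 (0.21 log units; within the scatter) is the closest guide. Alongside it, a 1.3-fold lower number from compound 1 to compound 2 (0.13 log units; within the scatter) shows another small move among these three compounds. Among the measured compounds shown here, these steps suggest only that the group in this region has so far changed the number little in this assay and they cannot exclude a larger move in either direction. The expected step is a 1.2-fold lower number from compound 3 to compound 4 (0.09 log units; within the scatter) and no shift beyond the scatter is expected. Compound 4 is estimated at 6 nM in this assay with an expected range from 2 nM to 20 nM for this compound.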

Compound 4, half-maximal inhibitory concentration: 4.6 nM
Compound 4: middle estimate off by 1.3-fold (0.12 log units), on the high side, and the stated range covers the measured number.
By their numbers in this assay, from the lowest: compounds 2, 1, 4 and 3 (each within the scatter of the next, the first and the last beyond it).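

Among these compounds, compound 4 gives the first reading on the amine nitrogen in the ring of compound 3, which the earlier steps on the aromatic carbon and on the nitrogen on an aromatic ring never touched, and in this assay the outcome is a 1.6-fold lower number from compound 3 to compound 4 (0.20 log units; within the scatter) so the two compounds cannot be told apart. Among the compounds shown here, a phenylsulfonyl group, with its 9 heavy atoms and its six-membered aromatic ring of carbon only, can therefore take the place of hydrogen on that nitrogen without the number leaving the scatter, a latitude that the earlier compounds gave no means of judging. Nothing measured here accounts for this result or says what the added group does at this position.

The single substitution leaves open whether this latitude holds for other groups on the same nitrogen, such as a small methyl, an acetyl or a benzoyl, where the sulfonyl link gives way to a carbonyl. It also leaves open whether a methoxy group or a chlorine on the new phenyl ring would shift the number, or whether the same phenylsulfonyl group would behave alike on a different amine in this position.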